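Carboxy on the pyrazole of compound 2: expected read-out

The source may report more compounds than this note shows. Statements on the series, on what has been measured and on what is new or still open speak of the compounds shown alone.

Working notes on a set of benzimidazole-linked piperazine amides tested in a functional assay on Venous blood for antagonist activity at C-X-C chemokine receptor type 3 (Homo sapiens), read by flow cytometry, with a stated time of 30 min, in the presence of a further agent that is not named here; on this read-out lower numbers stand for stronger inhibition and higher numbers for weaker inhibition. Compound 1 `C[C@@H]1CN(c2sc(C(F)(F)F)nc2-c2nc3cc(OCCO)ccc3[nH]2)CCN1C(=O)Cn1cnc2cccnc21` gives 99.1 nM. Compound 2 `C[C@@H]1CN(c2sc(C(F)(F)F)nc2-c2nc3ccccc3[nH]2)CCN1C(=O)Cn1cccn1` gives 191 nM. Compound 3 `Cc1nc(C)n(CC(=O)N2CCN(c3sc(C(F)(F)F)nc3-c3nc4ccc(C(C)(C)O)c(F)c4[nH]3)C[C@H]2C)n1` gives 628 nM. On these three numbers compound 2 stands second highest; its gap to compound 1 lies within the usual scatter, so the two are not told apart, while compound 3 gives a clearly higher number than compound 2, a gap beyond the scatter.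

The step under study goes from compound 2 to compound 4 `C[C@@H]1CN(c2sc(C(F)(F)F)nc2-c2nc3ccccc3[nH]2)CCN1C(=O)Cn1ccc(C(=O)O)n1`, not yet measured in this assay. The change is carboxy in place of hydrogen on an aromatic carbon. Going by the values given here, no pair among the measured compounds shows this change, so the size of the step cannot be read from them; the three measured values together only span the range in which the series has so far been found.

The expectation is that compound 4 gives a weaker read-out than compound 2, with a step of a 2.4-fold higher number from compound 2 to compound 4 (0.37 log units; beyond the scatter) that lies beyond the scatter. For compound 4 the estimate in this assay is 450 nM, with a range from 130 nM to 1600 nM.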

Compound 4, half-maximal inhibitory concentration: 5570 nM
Estimate against measurement, compound 4: 12-fold (1.09 log units) below; the whole stated range lies below it.
By their numbers in this assay, from the lowest: compounds 1 and 2 (each within the scatter of the next); then compound 3; then compound 4.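

In this assay, going by these compounds alone, the step is a 29-fold higher number from compound 2 to compound 4 (1.46 log units; beyond the scatter) for carboxy in place of hydrogen on an aromatic carbon, and this is the first change that can be read on its own, since the earlier compounds differ from one another in more than one place. It shows that the read-out is far from indifferent to what this carbon of the pyrazole carries: going from 1H-pyrazol-1-yl to 3-carboxy-1H-pyrazol-1-yl leaves compound 4 at 5570 nM and so gives a clearly weaker read-out than the unsubstituted ring. No measurement at hand accounts for the size of this step, which rests on a single pair.

Going by these compounds, it remains open whether the loss belongs to the carboxy group itself or to any added group on this carbon; a methyl ester, a primary carboxamide or a hydroxymethyl group in the same place would separate these cases. On these data alone, it is also open whether a carboxylic acid on a different carbon of the pyrazole would give a step of similar size.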